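The source may report more compounds than this note shows. Statements on the series, on what has been measured and on what is new or still open speak of the compounds shown alone.

Of the compounds shown here, three sharing one core have been tested in an ADME assay on microsomes from liver (Homo sapiens) for metabolic stability, read by LC-MS, with a stated time of 1 h, tested at 1 uM; on this read-out lower numbers stand for a less stable compound and higher numbers for a more stable compound. Compound 1, `O=[N+]([O-])c1cn2c(n1)OC[C@@H](OCCCC#Cc1ccc(OC(F)(F)F)cc1)C2`, gives 69%. Compound 2, `O=[N+]([O-])c1cn2c(n1)OC[C@@H](OC/C=C/c1ccc(-c3ccc(OC(F)(F)F)cc3)cc1)C2`, gives 100%. Compound 3, `O=[N+]([O-])c1cn2c(n1)OC[C@@H](OCCCc1ccc(-c3ccc(OC(F)(F)F)cc3)cc1)C2`, gives 88%. Among these three numbers compound 3 stands second highest: its nearest neighbour is compound 2, whose number lies higher by a gap beyond the usual scatter, and its furthest is compound 1, whose number lies lower, again beyond the scatter.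

Compound 4, `O=[N+]([O-])c1cn2c(n1)OC[C@@H](OCCCc1ccc(-c3ccc(C(F)(F)F)cc3)cc1)C2`, differs from compound 3 in a single place (trifluoromethyl in place of trifluoromethoxy on an aromatic carbon). For the measured compounds named here, no measured pair shows this particular exchange, so there is no measured step to lean on, and the expectation rests on compound 3 alone. The expected step is a number 4 percentage points lower from compound 3 to compound 4 (within the scatter), which is taken to lie within the usual scatter, leaning slightly downward but not clearly so. The estimate for compound 4 in this assay is therefore 84%, with a range from 65% to 100%.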

Compound 4, percent of the compound remaining: 73%
Compound 4: the middle estimate sits 11 percentage points above what was measured; low and high end bracket the measured number.
By their numbers in this assay, from the lowest: compounds 1 and 4 (each within the scatter of the next); then compound 3; then compound 2.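

In this assay, putting trifluoromethyl in place of trifluoromethoxy gives a number 15 percentage points lower from compound 3 to compound 4 (beyond the scatter), so the group para to the large group on this aromatic ring does matter to the read-out, and losing the oxygen of the trifluoromethoxy group is not a neutral exchange here. For the compounds shown here, this is the first pair in the set that differs in only one place, which makes it the only direct reading of any single change so far. Nothing available explains why the number moves in this direction.

As far as these compounds go, how a nitrile, a chlorine or a methoxy group at this place would compare with trifluoromethoxy stays open. Also open, from the compounds shown here alone, is whether the same exchange would give a similar step on the different chains of compound 1 and compound 2, since a single pair cannot show that.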